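A few compounds are considered here, and "the series" means these few. Any claim that something is new, unique, unknown or untested is made for them only; others in the source may bear on it.

In an ADME assay on HepG2 cells (Homo sapiens) for cytotoxicity, read by MTT assay, with a stated time of 48 h (on this read-out lower numbers stand for higher toxicity in this test and higher numbers for lower toxicity in this test), compound 1 `COc1cc(NC(C)CCCNC(=O)c2c(C)[n+]([O-])c3ccccc3[n+]2[O-])c2ncccc2c1` gives 39500 nM and compound 3 `COc1cc(NC(C)CCCNC(=O)c2c(C)[n+]([O-])c3ccc(C)cc3[n+]2[O-])c2ncccc2c1` gives 110000 nM. Compound 2 `COc1cc(NC(C)CCCNC(=O)c2c(C)[n+]([O-])c3ccc(OC)cc3[n+]2[O-])c2ncccc2c1` reads > 203000 nM, which is a limit of the assay and not a number. Compound 3 therefore holds the higher of the two exact numbers. Compound 4 `COc1cc(NC(C)CCCNC(=O)c2c(C)[n+]([O-])c3cc(C)c(C)cc3[n+]2[O-])c2ncccc2c1` differs from compound 3 by a single change: methyl in place of hydrogen on an aromatic carbon. Going by the values given here, the closest precedent is the same exchange, a 2.8-fold higher number from compound 1 to compound 3 (0.44 log units; beyond the scatter). Methoxy in place of hydrogen ran the same way, an at least 5.1-fold higher number from compound 1 to compound 2 (0.71 log units; beyond the scatter). A small upward step in this assay, possibly within the scatter, is therefore expected. The expected step is a 1.5-fold higher number from compound 3 to compound 4 (0.19 log units; within the scatter). For compound 4 the estimated value is 170000 nM, with an expected range from 80000 nM to 350000 nM.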

Compound 4, half-maximal cytotoxic concentration: > 202000 nM
Compound 4 was reported as a limit (the forecaster's own chance of this, stated with the estimate: 30%); at least 1.1-fold (0.07 log units) between middle value and limit.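

In this assay, the methyl ortho to a methyl group gives an at least 1.8-fold higher number from compound 3 to compound 4 (0.26 log units; that floor lies within the scatter). This shows that a methyl at this position, on a ring that already carries one, does not bring the number back down, although the floor of the step alone does not establish a rise. The reading of compound 4 is a limit and not a number: the limit of > 202000 nM in this assay, at which 1 of the 4 values shown sits.

On these data alone, the true numbers of compound 2 and compound 4 stay open, so those two cannot be ordered. As far as these compounds go, whether an amine or a carboxylic acid on this aromatic carbon would run the same way also remains open.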